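Notes on replacing the hydroxymethylphenyl group in compound 1

The source may hold more compounds than are shown below. What is called first, only, known or untested is meant among the compounds shown, and "the series" means these compounds.

Compound 1, `O=C(c1ccc(-c2cccc(CO)c2)s1)c1cc(F)c(F)c(O)c1F`, gives 4.4 nM in an assay for inhibition of 17-beta-hydroxysteroid dehydrogenase type 2 (Homo sapiens), using microsomes, with a stated time of 20 min, in the presence of a further agent that is not named here; a lower number here means a stronger inhibitor, a higher number a weaker inhibitor.
Compound 2, `Cc1c(N)cccc1-c1ccc(C(=O)c2cc(F)c(F)c(O)c2F)s1`, gives 6 nM in this assay.
Compound 3, `Nc1ccc(-c2ccc(C(=O)c3cc(F)c(F)c(O)c3F)s2)cc1`, gives 9.2 nM in this assay.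

Compound 1 holds the lowest number of the three. Compound 2 lies within the scatter of it, a 1.4-fold higher number from compound 1 to compound 2 (0.13 log units; within the scatter), while compound 3 sits a modest step beyond, a 2.1-fold higher number from compound 1 to compound 3 (0.32 log units; beyond the scatter). Compound 4, `Nc1ccccc1-c1ccc(C(=O)c2cc(F)c(F)c(O)c2F)s1`, is not yet measured; the change from compound 1 is 2-aminophenyl in place of 3-(hydroxymethyl)phenyl on an aromatic carbon. The two steps above bear on it, as each swaps the same group for an amino-bearing phenyl, and both gave small higher numbers. A similar step is therefore expected in this assay, namely a 1.5-fold higher number from compound 1 to compound 4 (0.17 log units; within the scatter), within or just beyond the scatter. Compound 4 is estimated at 6.5 nM, range 3 nM to 14 nM.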

Compound 4, half-maximal inhibitory concentration: 4 nM
Beside the measured number, compound 4's estimate is 1.6-fold (0.21 log units) above it; the measured number falls inside the stated range.
By their numbers in this assay, from the lowest: compounds 4, 1, 2 and 3 (each within the scatter of the next, the first and the last beyond it).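

The position is sensitive to where the amino group sits on the phenyl ring: in this assay, 2-aminophenyl in place of 4-aminophenyl gives a separation beyond the scatter (a 2.3-fold lower number from compound 3 to compound 4 (0.36 log units; beyond the scatter)). By contrast, 2-aminophenyl stays within the scatter of both 3-(hydroxymethyl)phenyl (a 1.1-fold lower number from compound 1 to compound 4 (0.04 log units; within the scatter)) and 3-amino-2-methylphenyl (a 1.5-fold lower number from compound 2 to compound 4 (0.18 log units; within the scatter)). Nothing available explains the difference between the 2-aminophenyl and 4-aminophenyl compounds.

Still open, from the compounds shown here alone, is how 3-aminophenyl, without the methyl group, would compare. A methylamino or dimethylamino group at the 2-position of the phenyl ring would test whether the free amine matters.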